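Cyclopropyl for fluorophenyl on the tetrazole: an expected Emax

The source may hold more compounds than are shown below. What is called first, only, known or untested is meant among the compounds shown, and "the series" means these compounds.

Of the compounds shown here, three have been tested in an assay on HEK293 cells for activation of Kir3.1/Kir3.2 (Homo sapiens), read by thallium flux; on this read-out higher numbers stand for larger maximal responses and lower numbers for smaller maximal responses. Compound 1 `Cc1cc(NC(=O)Cn2nnc(-c3ccccc3)n2)n(C2CCS(=O)(=O)CC2)n1` gives > 25%, which is a limit of the assay and not a number. Compound 2 `O=C(Cn1nnc(-c2ccccc2)n1)Nc1cc(C2CC2)nn1C1CCCCC1` gives 45%. Compound 3 `Cc1cc(NC(=O)Cn2nnc(-c3ccccc3F)n2)n(C2CCCCC2)n1` gives 88%, the highest of the two numbers obtained; compound 2 sits far lower, a gap that lies beyond the usual scatter. Among the compounds with values here, no pair of measured compounds differs in only one place, so no single structural step has yet been measured.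

Compound 4 `Cc1cc(NC(=O)Cn2nnc(C3CC3)n2)n(C2CCCCC2)n1` is not yet measured. It differs from compound 3 in one place: cyclopropyl in place of 2-fluorophenyl on an aromatic carbon. Compound 2 also carries a cyclopropyl, but elsewhere and together with other changes, so it gives no direct guide.

With the aromatic ring gone from that position, a step downward beyond the scatter is expected, roughly a number 28 percentage points lower from compound 3 to compound 4 (beyond the scatter). Compound 4 is therefore expected to reach about 60%, within a range from 30% to 90%.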

Compound 4, largest response reached (Emax), in percent of the reference or control that the assay uses: > 68%
Compound 4: only a limit was reported; the forecaster's own chance of this, stated with the estimate: 10%; middle value at least 8 percentage points away from the limit.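

In this assay compound 4 gives > 68%, which is a limit of the assay and not a number. The step between compound 3 and compound 4 therefore cannot be read. The compounds shown leave open how far cyclopropyl in place of 2-fluorophenyl changes the maximal response, if at all.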